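Removing the pentyl group from compound 3

The source may hold more compounds than are shown below. What is called first, only, known or untested is meant among the compounds shown, and "the series" means these compounds.

Of the compounds shown here, three sharing one core have been measured in a functional assay on RAW264.7 cells (Mus musculus) for inhibition, read by Griess assay, with stated times of 1 h and 24 h; on this read-out higher numbers stand for weaker inhibition and lower numbers for stronger inhibition. Compound 1 (`CCCOc1ccccc1C1CC(=O)c2ccccc2O1`) gives 46000 nM, compound 2 (`CC(C)c1ccc(COc2ccccc2C2CC(=O)c3ccccc3O2)cc1`) gives 27100 nM, and compound 3 (`CCCCCOc1ccccc1C1CC(=O)c2ccccc2O1`) gives 39200 nM. Compound 3 therefore stands within the scatter of both others, as the data show a 1.2-fold lower number from compound 1 to compound 3 (0.07 log units; within the scatter) and a 1.4-fold higher number from compound 2 to compound 3 (0.16 log units; within the scatter).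

Compound 4 (`O=C1CC(c2ccccc2O)Oc2ccccc21`) carries hydrogen in place of pentyl on an oxygen on an aromatic ring, (hydrogen in place of pentyl on an oxygen on an aromatic ring). For the measured compounds named here, no measured step removes the chain altogether, so the evidence is indirect. Exchanging the group on that oxygen gave a 1.7-fold lower number from compound 1 to compound 2 (0.23 log units; within the scatter), and extending the chain gave a 1.2-fold lower number from compound 1 to compound 3 (0.07 log units; within the scatter). Neither step leaves the scatter, so no step beyond the scatter is expected in this assay, in either direction. As far as these compounds go, whether this holds for pentyloxy to hydroxy is untested, which calls for a wide range. The estimated change is a 1.0-fold higher number from compound 3 to compound 4 (0.01 log units; within the scatter). For compound 4 the expected value is 40000 nM, with an estimated range from 15000 nM to 90000 nM.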

Compound 4, half-maximal inhibitory concentration: 71300 nM
For compound 4 the middle estimate is 1.8-fold (0.25 log units) below the measured one, within the range that was stated.
By their numbers in this assay, from the lowest: compounds 2, 3, 1 and 4 (each within the scatter of the next, the first and the last beyond it).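

In this assay, removing the chain from the oxygen to leave hydroxy stays within the scatter, both for pentyl (with a 1.8-fold higher number from compound 3 to compound 4 (0.26 log units; within the scatter)) and for propyl (with a 1.6-fold higher number from compound 1 to compound 4 (0.19 log units; within the scatter)). Neither chain is thus shown to matter for the read-out at this position, although compound 2 (27100 nM) and compound 4 (71300 nM) lie beyond the scatter of each other, the only such pair among the four compounds. Nothing measured here gives a reason for these numbers.

The compounds shown leave open whether a different group on this oxygen, such as a carboxylic acid, an amine on a chain or a chain longer than pentyl, would stand clearly apart from hydroxy. They also leave open whether a smaller group, such as methyl, would differ from hydroxy at all.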